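The source may report more compounds than this note shows. Statements on the series, on what has been measured and on what is new or still open speak of the compounds shown alone.

Compound 1 `O=C(NCc1ccc(S(=O)(=O)c2cccc(C(F)(F)F)c2)cc1)c1cc2cnccc2[nH]1` gives 8 nM in an assay for inhibition of Nicotinamide phosphoribosyltransferase (Homo sapiens), read by mass spectrometry, with stated times of 15 min and 30 min; a lower number here means a stronger inhibitor, a higher number a weaker inhibitor.
Compound 2 `Cn1c(C(=O)NCc2ccc(S(=O)(=O)c3ccccc3)cc2)cc2ccncc21` gives 410 nM in this assay.
Compound 3 `O=C(NCc1ccc(S(=O)(=O)N2CCCCC2)cc1)c1cc2ccncc2[nH]1` gives 1000 nM in this assay.

Among these three, compound 3 stands at the highest number, meaning the weakest inhibition of the set. Its nearest neighbour is compound 2, whose number is lower by a step that lies beyond the usual scatter, and the furthest is compound 1, whose number is lower by a wide margin, also beyond the scatter.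

Compound 4 `O=C(NCc1ccc(S(=O)(=O)N2CCCCC2)cc1)c1ccc2nc[nH]c2c1` has not yet been measured. It keeps the whole sulfonyl-piperidine benzylamide part of compound 3 and changes only the aromatic head on the carbonyl: a group of 9 heavy atoms (7 carbon, 2 nitrogen; one five-membered aromatic ring with 2 hetero atoms, one six-membered aromatic ring of carbon only) in place of a group of 9 heavy atoms (7 carbon, 2 nitrogen; one five-membered aromatic ring with 1 hetero atom, one six-membered aromatic ring with 1 hetero atom), on a carbonyl carbon. The two compounds share every atom, joined differently.

Going by the values given here, no pair of measured compounds differs in exactly this way, so the size of the step has to be judged from compound 3 alone. Within this small set, the head group on the carbonyl is where the numbers spread most, so a step beyond the scatter in either direction is possible; a drift toward a higher number seems somewhat more likely than a gain. Compound 4 is therefore expected to give about 2500 nM, within a range of 600 nM to 10000 nM, which corresponds to an estimated step of a 2.5-fold higher number from compound 3 to compound 4 (0.40 log units; beyond the scatter).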

Compound 4, half-maximal inhibitory concentration: 310 nM
Compound 4: middle estimate off by 8.1-fold (0.91 log units), on the high side; measured number below the stated range.
By their numbers in this assay, from the lowest: compound 1; then compounds 4 and 2 (each within the scatter of the next); then compound 3.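

Going by these compounds alone, with the sulfonyl-piperidine benzylamide part held fixed, placing 1H-benzimidazol-6-yl on the carbonyl carbon gives a 3.2-fold lower number from compound 3 to compound 4 (0.51 log units; beyond the scatter) in this assay, the first reading in this set of what the head group does on its own. The two heads have the same atoms and the same counts of hydrogen-bond donors and acceptors, yet rejoining those atoms, with both nitrogens now in the five-membered ring and the six-membered ring of carbon only, is enough for a step beyond the scatter. Nothing available here accounts for the size or direction of this step, so it stands as an observation only.

The compounds shown leave open whether 1H-benzimidazol-6-yl would give a similar step with a phenyl group in place of the piperidine, since this head is seen only with the sulfonyl-piperidine part. They also leave open how the head would respond to a substituent such as a chlorine or an amine on its six-membered ring, and how a morpholine in place of the piperidine would compare.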